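Amino in place of hydroxy: notes on compound 3

The source may hold more compounds than are shown below. What is called first, only, known or untested is meant among the compounds shown, and "the series" means these compounds.

Values in a functional assay on A549 cells (Homo sapiens) for antiproliferative activity, read by MTT assay, with a stated time of 48 h; a lower number here means a stronger inhibitor, a higher number a weaker inhibitor
compound 1 `COc1ccc(-c2nc3cccc(-c4cc(OC)c(OC)c(OC)c4)c3o2)cc1` gives 2200 nM
compound 2 `COc1cc(-c2cccc3nc(-c4cccc(O)c4)oc23)cc(OC)c1OC` gives 2000 nM

The two values lie within the scatter of each other, so compound 2 stands level with compound 1 on these numbers. Compound 3 `COc1cc(-c2cccc3nc(-c4cccc(N)c4)oc23)cc(OC)c1OC` differs from compound 2 by amino in place of hydroxy on an aromatic carbon. For the measured compounds named here, the one measured step that bears on this is a 1.1-fold lower number from compound 1 to compound 2 (0.04 log units; within the scatter) (within the scatter), and no measured compound carries the amino group. An estimated 1.1-fold lower number from compound 2 to compound 3 (0.05 log units; within the scatter) is therefore expected in this assay (none beyond the scatter). The expected value for compound 3 is 1800 nM (range 700 nM to 4500 nM).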

Compound 3, half-maximal inhibitory concentration: 4700 nM
Beside the measured number, compound 3's estimate is 2.6-fold (0.42 log units) below it; the measured number lies above the stated range.
By their numbers in this assay, from the lowest: compounds 2 and 1 (each within the scatter of the next); then compound 3.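

The group on this aromatic carbon does matter: amino in place of hydroxy gives a 2.4-fold higher number from compound 2 to compound 3 (0.37 log units; beyond the scatter), although both groups count the same under the computed comparison, whereas the earlier pair showed no step beyond the scatter. 3-Aminophenyl also stands apart from 4-methoxyphenyl, with a 2.1-fold higher number from compound 1 to compound 3 (0.33 log units; beyond the scatter), so compound 3 is the weakest of the three. Nothing on hand accounts for these steps.

On these data alone, whether a methylamino group or a carboxylic acid on this aromatic carbon would read like hydroxy or like amino remains open.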